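Phenyl Traded for Bromo: Expecting Little Movement

The compounds below may be only part of what the source reports. "The series", "measured", "known", "first", "only" and "open" are said of these compounds alone.

Three compounds have been tested in an assay on isolated protein for inhibition of Indoleamine 2,3-dioxygenase 1 (Homo sapiens), read by spectrophotometry; a higher number here means a weaker inhibitor, a lower number a stronger inhibitor:
compound 1 `O=C(Cc1cccnc1)c1cc2c(Cl)cc(Cl)cc2[nH]1` gives 139000 nM;
compound 2 `O=C(Cc1cccnc1)c1cc2cc(-c3ccccc3)ccc2[nH]1` gives 96000 nM;
compound 3 `O=C(Cc1ccncc1)c1cc2ccccc2[nH]1` is reported as "not active" (no number reported).

Compound 2 has the lower of the two numbers, but its gap to compound 1 lies within the usual scatter, so the two cannot be ranked against each other. Compound 4 `O=C(Cc1cccnc1)c1cc2cc(Br)ccc2[nH]1` differs from compound 2 in one place: bromo in place of phenyl on an aromatic carbon. Going by the values given here, no measured pair shows what this kind of change does here, so nothing points in either direction, and a step no larger than the scatter seems most likely. Compound 4 is therefore estimated at 100000 nM in this assay, with a range from 30000 nM to 300000 nM. The expected step is a 1.0-fold higher number from compound 2 to compound 4 (0.02 log units; within the scatter).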

Compound 4, half-maximal inhibitory concentration: 18000 nM
Estimate against measurement, compound 4: 5.6-fold (0.74 log units) above; the whole stated range lies above it.
By their numbers in this assay, from the lowest: compound 4; then compounds 2 and 1 (each within the scatter of the next).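

In this assay, going by these compounds alone, bromo in place of phenyl on an aromatic carbon gives a 5.3-fold lower number from compound 2 to compound 4 (0.73 log units; beyond the scatter) and this is the first step that goes beyond the scatter. This position on the shared core therefore responds to what sits there, and the phenyl ring is not required for activity, as a single bromine atom serves better here. Nothing at hand explains the gain. On these data alone, it remains open whether a methoxy group, an amine or a fluoro group at this position would match bromo. As far as these compounds go, it also remains open whether any group here could bring the numbers much lower.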